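Removing the bromoacrylamide from compound 3

The compounds below may be only part of what the source reports. "The series", "measured", "known", "first", "only" and "open" are said of these compounds alone.

Within the data shown here, compound 3 `C=C(Br)C(=O)Nc1cccc(-c2cn3nc(Cc4ccc(Cl)cc4)sc3n2)c1` is one of three compounds measured in a functional assay on FM3A cells (Mus musculus) for inhibition, read by cell counting, with a stated time of 2 days; on this read-out lower numbers stand for stronger inhibition and higher numbers for weaker inhibition. Compound 3 gives 1100 nM, and compound 1 `C=C(Br)C(=O)Nc1cccc(-c2cn3nc(-c4ccc(OCC)cc4)sc3n2)c1` gives 1100 nM; the step of no change at the digits printed from compound 1 to compound 3 (within the scatter) lies within the scatter, so these two stand level as the lowest numbers of the set. Compound 2 `Nc1cccc(-c2cn3nc(CCc4ccccc4)sc3n2)c1` gives 29000 nM, a markedly higher number. Compound 4 `Nc1cccc(-c2cn3nc(Cc4ccc(Cl)cc4)sc3n2)c1` has not yet been measured; it differs from compound 3 by hydrogen in place of (1-bromoethenyl)carbonyl on a nitrogen on an aromatic ring. Among the measured compounds shown here, no measured step covers this exact change. For the measured compounds named here, the only compound bearing a free amine at that position, compound 2, shows a far higher number than either acylated compound, although it also differs from them elsewhere. On that basis compound 4 is expected to give a much higher number in this assay, a step estimated at a 23-fold higher number from compound 3 to compound 4 (1.36 log units; beyond the scatter). The estimate for compound 4 is 25000 nM, with a range from 8000 nM to 80000 nM.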

Compound 4, half-maximal inhibitory concentration: 6000 nM
The estimate for compound 4 lay 4.2-fold (0.62 log units) above the measured number; measured number outside the range, below it.
By their numbers in this assay, from the lowest: compounds 1 and 3 (each within the scatter of the next); then compound 4; then compound 2.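

In this assay, the change at this nitrogen now has a direct reading on an otherwise unchanged structure: going from ((1-bromoethenyl)carbonyl)amino to amino gives a modest loss (a 5.5-fold higher number from compound 3 to compound 4 (0.74 log units; beyond the scatter)), and the free amine still gives a measured number well short of that of compound 2. The free amines also differ among themselves (a 4.8-fold lower number from compound 2 to compound 4 (0.68 log units; beyond the scatter)), so the high number of compound 2 goes partly with benzyl in place of 4-chlorophenyl on the saturated chain carbon and not with the amino group alone. The data shown offer no measurement that accounts for either step.

As far as these compounds go, it remains open whether the bromine or the carbonyl carries the difference, since a plain acetyl or acryloyl group on this nitrogen does not appear here. From the compounds shown here alone, how the same change reads with the 4-ethoxyphenyl group of compound 1 also stays open.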